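A few compounds are considered here, and "the series" means these few. Any claim that something is new, unique, unknown or untested is made for them only; others in the source may bear on it.

Compound 1 `C/C=C/COC(=O)/C=C(C)/C=C/CC(C)CCCC(C)(C)OC` is the most lipophilic of the three compounds measured in a physicochemical assay for lipophilicity (a higher number here means a more lipophilic compound, a lower number a more polar compound), where compound 1 gives 6.07. Nearest to it stands compound 2 `CCNC(=O)OC(C)(C)CCCC(C)C/C=C/C(C)=C/C(=O)OCC`, which in this assay gives 5.65, a gap beyond the usual scatter. Furthest from it stands compound 3 `COC(CCC(C)C/C=C/C(C)=C/C(=O)OC(C)C)C(C)(C)OC`, which in this assay gives 4.75, also beyond the scatter. No pair among these three differs in one place only, so no single structural step has been measured.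

The step from compound 1 leads to compound 4 `COC(C)(C)CCCC(C)C/C=C/C(C)=C/C(=O)CC(C)C`, which has not yet been measured. The change is isobutyl in place of (but-2-en-1-yl)oxy on a carbonyl carbon: a group with one hydrogen-bond acceptor and one double bond outside aromatic rings leaves, and a group with no acceptor enters, one heavy atom smaller. Within the data shown here, no measured step covers this change, so the expectation rests on the structures alone. Compound 4 is expected to stay close to compound 1, with a step of a number 0.03 log units higher from compound 1 to compound 4 (within the scatter), none beyond the scatter. The estimate for compound 4 in this assay is 6.1, within 5.5 to 6.7.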

Compound 4, partition coefficient: 6.02
Beside the measured number, compound 4's estimate is 0.08 log units above it; the measured number falls inside the stated range.
By their numbers in this assay, from the lowest: compound 3; then compound 2; then compounds 4 and 1 (each within the scatter of the next).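

Among these compounds, this is the first step in the set that differs in one place only, and in this assay it reads a number 0.05 log units lower from compound 1 to compound 4 (within the scatter), so the two compounds cannot be told apart in this read-out. On this carbonyl carbon, isobutyl can thus stand in place of (but-2-en-1-yl)oxy, with one hydrogen-bond acceptor, one double bond and one heavy atom fewer, and the number stays within the scatter. No measured evidence accounts for this result.

The compounds shown leave open whether other groups on this carbonyl carbon, such as an amine or a hydroxyl giving a carboxylic acid, would also stay within the scatter. They also leave open whether a longer chain than isobutyl would do so.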